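Adding an Amino Group to a Weak Inhibitor's Acid Chain

This account rests on a few compounds, and the source may have more. Where it says the series, first, only, none or still open, it means among the compounds named here.

Compound 1, with the structure `COc1cc2c(cc1O)CCC(C)(CC(=O)O)O2`, carries a carboxymethyl chain on its core. In a functional assay on SH-SY5Y cells (Homo sapiens) for inhibition, read by fluorescence, with a stated time of 1 h (a lower number here means a stronger inhibitor, a higher number a weaker inhibitor), compound 1 gives 32300 nM, the lowest of the two plain numbers in this set. Compound 2, `COc1cc2c(cc1O)CCC(C)(CC(=O)N[C@H](C(=O)O)C(C)C)O2`, gives 43800 nM in this assay; the step of a 1.4-fold higher number from compound 1 to compound 2 (0.13 log units; within the scatter) is within the scatter, so the two cannot be ranked against each other. Compound 3, `COc1cc2c(cc1O)CCC(C)(CCNC(=O)/C=C(C)/C=C/C=C(C)/C=C/C1=C(C)CCCC1(C)C)O2`, reaches only the limit of this assay, reported as > 300000 nM.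

Compound 4, `COc1cc2c(cc1O)CCC(C)(CC(N)C(=O)O)O2`, differs from compound 1 by amino(carboxy)methyl in place of carboxy on a saturated chain carbon bound to a saturated ring carbon. Going by the values given here, the one measured step that bears on this place is the step from compound 1 to compound 2, where the hydroxy on the carbonyl carbon was replaced by an amino acid residue and the number moved only within the scatter. Among the compounds with values here, compound 4 keeps the free carboxy and adds an amino group on the chain beside it, a smaller change than the one that gave compound 2. The expected step of a 1.1-fold higher number from compound 1 to compound 4 (0.05 log units; within the scatter) is therefore small, with no direction beyond the scatter. Compound 4 is estimated at 36000 nM in this assay, with a range from 12000 nM to 110000 nM.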

Compound 4, half-maximal inhibitory concentration: > 200000 nM
Compound 4 was reported as a limit (the forecaster's own chance of this, stated with the estimate: 12%); middle value at least 5.5-fold (0.74 log units) away from the limit.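

Going by these compounds alone, replacing carboxy with amino(carboxy)methyl on a saturated chain carbon bound to a saturated ring carbon gives an at least 6.1-fold higher number from compound 1 to compound 4 (0.79 log units; beyond the scatter) in this assay, the first step in this set that lies beyond the scatter. The earlier change, which replaced the hydroxy on the carbonyl carbon with an amino acid residue, gave a 1.4-fold higher number from compound 1 to compound 2 (0.13 log units; within the scatter), so a large addition at that place left no readable mark, while a smaller one on the chain carbon did. The value of compound 4 is a limit and not a number: the limit of > 200000 nM in this assay, at which 1 of the 4 values shown sits.

The compounds shown leave open which part of the change matters, the added amino group or the longer chain that now carries the carboxy, and a chain with a methyl group in place of that amino group on the same carbon would separate the two. They also leave open whether the amine must stay free, a question that an acetamide at that carbon would address, and whether the same loss would appear with the amine on the chain but the carboxylic acid replaced by its methyl ester.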